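The source may report more compounds than this note shows. Statements on the series, on what has been measured and on what is new or still open speak of the compounds shown alone.

Measured in a functional assay on Caco-2 cells (Homo sapiens) for antiproliferative activity, read by MTT assay, with a stated time of 48 h; a higher number here means a weaker inhibitor, a lower number a stronger inhibitor:
- Compound 1 `CCN(CC)CCNC(=O)c1ccc(C(CC)(CC)c2ccc(OCCC(O)(CC)CC)c(C)c2)n1CC`: 1630 nM
- Compound 2 `CCn1c(C(=O)NCCN)ccc1C(CC)(CC)c1ccc(OCCC(O)(CC)CC)c(C)c1`: 1740 nM
- Compound 3 `CCn1c(C(=O)N(CCC#N)CCC#N)ccc1C(CC)(CC)c1ccc(OCCC(O)(CC)CC)c(C)c1`: > 50000 nM

The value for compound 3 is a limit of the assay and not a number, as the limit of > 50000 nM in this assay, at which 1 of the 3 values shown sits, shows.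

Compound 4 `CCn1c(C(=O)Nc2cccc(C(F)(F)F)c2)ccc1C(CC)(CC)c1ccc(OCCC(O)(CC)CC)c(C)c1` changes compound 3 on the carbonyl carbon: a group of 11 heavy atoms (7 carbon, 1 nitrogen, 3 fluorine; one six-membered aromatic ring of carbon only) in place of a group of 9 heavy atoms (6 carbon, 3 nitrogen; no ring), on a carbonyl carbon. The entering group is (3-(trifluoromethyl)phenyl)amino, and it restores the amide hydrogen that compound 1 and compound 2 carry and compound 3 lacks.

Among the compounds with values here, two measured steps bear on this: an at least 30-fold higher number from compound 1 to compound 3 (1.48 log units; beyond the scatter) and an at least 28-fold higher number from compound 2 to compound 3 (1.45 log units; beyond the scatter), both large. By contrast, a 1.1-fold higher number from compound 1 to compound 2 (0.03 log units; within the scatter) lies within the scatter, so the amide substituent does not always matter.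

A partial return towards stronger inhibition is therefore expected, with an estimated at least 7.1-fold lower number from compound 3 to compound 4 (0.85 log units; beyond the scatter). The estimate for compound 4 is 7000 nM, with a range of 1500 nM to 35000 nM.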

Compound 4, half-maximal inhibitory concentration: > 50000 nM
Compound 4: a limit, no number; the forecaster's own chance of this, stated with the estimate: 25%; at least 7.1-fold (0.85 log units) between middle value and limit.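

The result for compound 4 is a limit of the assay and not a number, and its step from compound 3 cannot be read, because both compounds sit at the same limit: the limit of > 50000 nM in this assay, at which 2 of the 4 values shown sit.

The amide hydrogen alone therefore does not bring back activity at this carbonyl carbon, since 3-(trifluoromethyl)phenyl on the amide-type nitrogen gives an at least 28-fold higher number from compound 2 to compound 4 (1.45 log units; beyond the scatter) and an at least 30-fold higher number from compound 1 to compound 4 (1.48 log units; beyond the scatter).

The compounds shown leave open whether a plain phenyl or a longer amine chain such as 3-aminopropyl on that nitrogen would keep activity.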